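The compounds below may be only part of what the source reports. "The series", "measured", "known", "first", "only" and "open" are said of these compounds alone.

Measured in a functional assay on CCRF-CEM cells (Homo sapiens) for antiproliferative activity, with a stated time of 72 h; on this read-out lower numbers stand for stronger inhibition and higher numbers for weaker inhibition:
- Compound 1 `OC[C@H]1O[C@@H](n2cnc3c(NCc4ccccc4Br)ncnc32)[C@H](O)[C@@H]1O`: 12300 nM
- Compound 2 `COc1cccc(CNc2ncnc3c2ncn3[C@@H]2O[C@H](CO)[C@@H](O)[C@H]2O)c1OC`: > 166000 nM (a limit)
- Compound 3 `COc1ccc(CNc2ncnc3c2ncn3[C@@H]2O[C@H](CO)[C@@H](O)[C@H]2O)c(OC)c1`: > 166000 nM (a limit)

Compound 3 stands at > 166000 nM, which is a limit and not a number. The same limit recurs across this small set: the limit of > 166000 nM in this assay, at which 2 of the 3 values shown sit.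

Compound 4 `COc1cc(CNc2ncnc3c2ncn3[C@@H]2O[C@H](CO)[C@@H](O)[C@H]2O)cc(OC)c1` differs from compound 3 only in the dimethoxyphenyl group on a saturated chain carbon bound to a nitrogen on an aromatic ring: 3,5-dimethoxyphenyl in place of 2,4-dimethoxyphenyl on a saturated chain carbon bound to a nitrogen on an aromatic ring.

The measured steps that bear on this change both start from the 2-bromophenyl group of compound 1. The first is an at least 13-fold higher number from compound 1 to compound 2 (1.13 log units; beyond the scatter), and the second is an at least 13-fold higher number from compound 1 to compound 3 (1.13 log units; beyond the scatter). Both are large and point toward weaker inhibition. The step between the two measured dimethoxyphenyl compounds is a step that the two limits leave unreadable from compound 2 to compound 3, so the data do not show how much the arrangement of the methoxy groups matters.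

Compound 4 also carries a dimethoxyphenyl group, so it is expected to resemble compound 3, with no step beyond the scatter and most likely another limit. The expected step is a number no higher from compound 3 to compound 4 (the limit leaves the size open). For compound 4 the estimated value is 166000 nM, with an expected range from 40000 nM to 300000 nM.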

Compound 4, half-maximal inhibitory concentration: > 166000 nM
Compound 4 gave a limit, no number; the forecaster's own chance of this, stated with the estimate: 70%; the middle value sits exactly at the limit.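

In this assay the 3,5-dimethoxyphenyl group also stands well apart from the 2-bromophenyl group, with an at least 13-fold higher number from compound 1 to compound 4 (1.13 log units; beyond the scatter). The steps among compound 2, compound 3 and compound 4 cannot be read, as both ends of each are limits, so nothing places these three dimethoxyphenyl compounds in an order. A third arrangement of the two methoxy groups on this ring has now ended at the same limit, which makes the result look less tied to one particular arrangement; among the compounds shown, only compound 1 goes against this pattern, and the set now reads: the limit of > 166000 nM in this assay, at which 3 of the 4 values shown sit.

From the compounds shown here alone, how far beyond the limit compound 2, compound 3 and compound 4 actually lie remains open, and so does any real difference among them. Also open, going by these compounds, is whether the loss follows from removing the bromine or from adding two methoxy groups, a question that a plain phenyl ring, a 2-chlorophenyl group or a ring with a single methoxy group at this place could help to settle.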